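Trifluoromethyl on the benzyl ring of compound 3

The compounds below may be only part of what the source reports. "The series", "measured", "known", "first", "only" and "open" are said of these compounds alone.

Compound 3 `Cc1cc(S(=O)(=O)/N=C(\N)n2nccc2-c2ccccc2)c(SCc2ccccc2)cc1Cl` has the lowest half-life of the three measured compounds: in an ADME assay on microsomes from liver (Homo sapiens) for metabolic stability, read by LC-MS, using NADPH, tested at 5 uM (a higher number here means that the compound lasts longer, a lower number that the compound disappears faster), compound 3 gives 0.0772 h, while compound 1 `Cc1cc(S(=O)(=O)/N=C(\N)n2nccc2-c2ccccc2)c(SCc2cccc(Cl)c2)cc1Cl` gives 0.309 h and compound 2 `Cc1cc(-c2ccccc2)n(/C(N)=N/S(=O)(=O)c2cc(C)c(Cl)cc2SCc2cccc(C(F)(F)F)c2)n1` gives 0.169 h. Compound 4 `Cc1cc(S(=O)(=O)/N=C(\N)n2nccc2-c2ccccc2)c(SCc2ccc(C(F)(F)F)cc2)cc1Cl` differs from compound 3 by trifluoromethyl in place of hydrogen on an aromatic carbon. Among the measured compounds shown here, the only measured step on that ring is a 4.0-fold lower number from compound 1 to compound 3 (0.60 log units; beyond the scatter), so removing a group from the benzyl ring lowered the number beyond the scatter; compound 4 adds a group there instead. On this basis, a rise is expected, a 2.8-fold higher number from compound 3 to compound 4 (0.45 log units; beyond the scatter), of similar size though its direction is inferred from one step only. Compound 4 is therefore estimated at 0.22 h, with a range from 0.08 h to 0.55 h.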

Compound 4, half-life: 0.176 h
Beside the measured number, compound 4's estimate is 1.3-fold (0.10 log units) above it; low and high end bracket the measured number.
By their numbers in this assay, from the lowest: compound 3; then compounds 2, 4 and 1 (each within the scatter of the next).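

In this assay, a group added to the benzyl ring of compound 3 raises the number directly, a 2.3-fold higher number from compound 3 to compound 4 (0.36 log units; beyond the scatter), so a second substituent, trifluoromethyl, now acts in the same direction as chloro. Exchanging 3-chlorophenyl for 4-(trifluoromethyl)phenyl gives a 1.8-fold lower number from compound 1 to compound 4 (0.24 log units; within the scatter), a step that lies within the scatter. No measurement here accounts for either step. As far as these compounds go, whether an amine or a methoxy group on this ring would also raise the number remains open. The step between compound 1 and compound 4 also changes both group and place, so their separate contributions remain unresolved.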